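Ester-side variation at the shared core: working notes

This account rests on a few compounds, and the source may have more. Where it says the series, first, only, none or still open, it means among the compounds named here.

Measured so far in an assay on membranes from HEK293 cells for displacement of a labelled ligand from adenosine receptor A2b (Homo sapiens), read by scintillation counting, with a stated time of 30 min; a lower number here means a stronger inhibitor, a higher number a weaker inhibitor:
compound 1 `CCCOC(=O)C1=C(C)NC(=O)NC1c1cccs1` gives 1520 nM
compound 2 `CC1=C(C(=O)OCC(C)C)C(c2cccs2)NC(=O)N1` gives 2130 nM

Of the two numbers, compound 2 gives the numerically larger one, but the step of a 1.4-fold higher number from compound 1 to compound 2 (0.15 log units; within the scatter) lies within the scatter, so the two compounds cannot be told apart on these data. Compound 3 `CC1=C(C(=O)OCc2ccccc2)C(c2cccs2)NC(=O)N1` is not yet measured. It differs from compound 2 by phenyl in place of isopropyl on a saturated chain carbon bound to an oxygen next to a carbonyl group. Among the measured compounds shown here, the only measured step, a 1.4-fold higher number from compound 1 to compound 2 (0.15 log units; within the scatter), sits on the same saturated chain and stays within the scatter; no measured step exchanges an isopropyl for a phenyl on that chain, so the direction of this change is unknown. On this basis the expected step of a 1.1-fold lower number from compound 2 to compound 3 (0.03 log units; within the scatter) in this assay is none beyond the scatter, with wide uncertainty. Compound 3 is therefore estimated at 2000 nM, with a likely range from 600 nM to 7000 nM.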

Compound 3, inhibition constant: 1920 nM
Compound 3: the middle estimate sits 1.0-fold (0.02 log units) above what was measured; measured number inside the range.
By their numbers in this assay, from the lowest: compounds 1, 3 and 2 (each within the scatter of the next).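

Compound 3 extends the ester side from open chains to an aromatic ring, and in this assay the number stays in the same range: phenyl in place of isopropyl gives a 1.1-fold lower number from compound 2 to compound 3 (0.05 log units; within the scatter), and phenyl in place of ethyl gives a 1.3-fold higher number from compound 1 to compound 3 (0.10 log units; within the scatter). Both steps lie within the scatter, so compound 1, compound 2 and compound 3 cannot be told apart, and at this position the exchange of a branched or straight chain for a six-membered aromatic ring shows no readable effect. No supporting information bears on this result.

The compounds shown leave open whether any group on this saturated chain carbon can move the number beyond the scatter. A carboxylic acid, an amine or a longer chain there remains an open case, as does a phenyl carrying a fluorine.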